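The compounds below may be only part of what the source reports. "The series", "measured", "known", "first", "only" and "open" are said of these compounds alone.

Measured so far in an ADME assay on liver (Mesocricetus auratus) for metabolic stability, using microsomes; on this read-out higher numbers stand for fast clearance and lower numbers for slow clearance
compound 1 `O=C(Nc1cc(-c2ccccn2)n[nH]1)N1CCC(c2ccccc2)CC1` gives 216 mL.min-1.g-1
compound 2 `O=C(Nc1cc(-c2ccccn2)n[nH]1)N1CCC(c2cccc(Cl)c2)CC1` gives 63.5 mL.min-1.g-1

Of these two numbers, compound 2 has the lower, at 63.5 mL.min-1.g-1. Among the compounds with values here, the only measured step is a 3.4-fold lower number from compound 1 to compound 2 (0.53 log units; beyond the scatter), with chloro in place of hydrogen on an aromatic carbon.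

Compound 3 `O=C(Nc1cc(-c2ccccn2)n[nH]1)N1CCC(Oc2ccccn2)CC1` has not been measured yet. Its difference from compound 2 is (pyridin-2-yl)oxy in place of 3-chlorophenyl on a saturated ring carbon. Compound 3 carries no chloro, so the measured step bears on it only in part, and some of a 3.4-fold lower number from compound 1 to compound 2 (0.53 log units; beyond the scatter) may be given back. Within the data shown here, no measured pair shows what the entering (pyridin-2-yl)oxy does in this assay, so the direction is a weak call and the range stays wide. The expected change is a 1.6-fold higher number from compound 2 to compound 3 (0.20 log units; within the scatter), a small rise at most in this assay. For compound 3 the estimated value is 100 mL.min-1.g-1, with an expected range from 35 mL.min-1.g-1 to 280 mL.min-1.g-1.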

Compound 3, intrinsic clearance in microsomes: 67.3 mL.min-1.g-1
Compound 3: the middle estimate sits 1.5-fold (0.17 log units) above what was measured; the measured number falls inside the stated range.
By their numbers in this assay, from the lowest: compounds 2 and 3 (each within the scatter of the next); then compound 1.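

In this assay, exchanging 3-chlorophenyl for (pyridin-2-yl)oxy on the saturated ring carbon gives a 1.1-fold higher number from compound 2 to compound 3 (0.03 log units; within the scatter), so the two compounds cannot be told apart, although the group that enters carries nitrogen and oxygen and no chlorine. Set against the phenyl of compound 1, (pyridin-2-yl)oxy gives a 3.2-fold lower number from compound 1 to compound 3 (0.51 log units; beyond the scatter), so among these three compounds a number well under that of compound 1 does not depend on chloro. Nothing measured on these compounds accounts for this result.

The compounds shown do not separate the contribution of the oxygen from that of the ring nitrogen within (pyridin-2-yl)oxy, so it remains open which of the two, if either, goes with the step from compound 1. Also open, going by these compounds, is how a phenoxy group, a pyridin-2-yl group without the oxygen, an amine or a carboxylic acid on the same saturated ring carbon would read in this assay, and whether a chloro on the ring of (pyridin-2-yl)oxy would shift the number further.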